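Three aryl chalcone boronates and a hydroxyphenyl successor

This account rests on a few compounds, and the source may have more. Where it says the series, first, only, none or still open, it means among the compounds named here.

Three compounds sharing one core were measured in a toxicity assay on MCF-10A cells (Homo sapiens) for cytotoxicity, read by MTT assay, with a stated time of 48 h; on this read-out lower numbers stand for stronger inhibition and higher numbers for weaker inhibition. Compound 1 `O=C(/C=C/c1ccc2c(c1)B(O)OC2)c1ccc(Cl)cc1` gives 12100 nM. Compound 2 `O=C(/C=C/c1ccc2c(c1)B(O)OC2)c1ccc(OCc2ccccc2)cc1` gives 23300 nM, and compound 3 `O=C(/C=C/c1ccc2c(c1)B(O)OC2)c1ccc([N+](=O)[O-])cc1` gives 17500 nM. The step of a 1.9-fold higher number from compound 1 to compound 2 (0.28 log units; within the scatter) and the step of a 1.4-fold higher number from compound 1 to compound 3 (0.16 log units; within the scatter) both stay within the scatter, as does the step of a 1.3-fold lower number from compound 2 to compound 3 (0.12 log units; within the scatter), so the three numbers cannot be told apart, and compound 1 simply stands among them with no separation from either neighbour.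

Compound 4 `O=C(/C=C/c1ccc2c(c1)B(O)OC2)c1cccc(O)c1` has not yet been measured. It differs from compound 1 in one place: 3-hydroxyphenyl in place of 4-chlorophenyl on a carbonyl carbon. Among the compounds with values here, no measured step bears directly on this change; the three measured steps all swap a group on an aromatic carbon of the same ring, and each stayed within the scatter. On that basis compound 4 is expected to land close to compound 1, with the step of a 1.2-fold higher number from compound 1 to compound 4 (0.09 log units; within the scatter) not beyond the scatter. The estimate for compound 4 in this assay is therefore 15000 nM, within a range of 7000 nM to 35000 nM.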

Compound 4, half-maximal inhibitory concentration: 25300 nM
The estimate for compound 4 lay 1.7-fold (0.23 log units) below the measured number; low and high end bracket the measured number.
By their numbers in this assay, from the lowest: compounds 1, 3, 2 and 4 (each within the scatter of the next, the first and the last beyond it).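

Among the compounds shown, replacing 4-chlorophenyl with 3-hydroxyphenyl on the carbonyl carbon is the first change to pass beyond the scatter in this assay, with a 2.1-fold higher number from compound 1 to compound 4 (0.32 log units; beyond the scatter), although the step is modest. Unlike the earlier swaps, this change replaces the group at the carbonyl carbon as a whole, bringing in a hydrogen-bond donor and acceptor where 4-chlorophenyl has neither, and it alters both the substituent and its number in the group's name. No measured evidence here accounts for the step.

The compounds shown leave open whether the step follows the hydroxyl itself or its place on the ring, a question that 3-chlorophenyl and 4-hydroxyphenyl groups could address. They also leave open how an amine or a carboxylic acid in place of the hydroxyl would read in this assay.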